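A few compounds are considered here, and "the series" means these few. Any claim that something is new, unique, unknown or untested is made for them only; others in the source may bear on it.

Measured so far:
- compound 1 `OC[C@H]1O[C@@H](n2cnc3c(NCc4ccccc4Br)ncnc32)[C@H](O)[C@@H]1O`: 6600 nM
- compound 2 `OC[C@H]1O[C@@H](n2cnc3c(NCc4cccc(Br)c4)ncnc32)[C@H](O)[C@@H]1O`: 8000 nM

In a functional assay on HL-60 cells (Homo sapiens) for antiproliferative activity, with a stated time of 72 h (a lower number here means a stronger inhibitor, a higher number a weaker inhibitor), compound 2 gives 8000 nM, which stands within the scatter of compound 1. Compound 3 `OC[C@H]1O[C@@H](n2cnc3c(NCc4ccc(Cl)c(Cl)c4)ncnc32)[C@H](O)[C@@H]1O` carries 3,4-dichlorophenyl in place of 3-bromophenyl on a saturated chain carbon bound to a nitrogen on an aromatic ring. Going by the values given here, only one measured step bears on this change, a 1.2-fold higher number from compound 1 to compound 2 (0.08 log units; within the scatter), and it exchanges 2-bromophenyl for 3-bromophenyl. Among the compounds with values here, no measured compound carries 3,4-dichlorophenyl, so the expectation is loose. The expected step, none beyond the scatter, is a 1.1-fold lower number from compound 2 to compound 3 (0.06 log units; within the scatter). For compound 3 the estimate is 7000 nM, with an expected range of 2500 nM to 20000 nM.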

Compound 3, half-maximal inhibitory concentration: 2000 nM
Estimate against measurement, compound 3: 3.5-fold (0.54 log units) above; measured number outside the range, below it.
By their numbers in this assay, from the lowest: compound 3; then compounds 1 and 2 (each within the scatter of the next).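

On a saturated chain carbon bound to a nitrogen on an aromatic ring, the aryl group can shift the number in this assay. The 3,4-dichlorophenyl exchange gives a 4.0-fold lower number from compound 2 to compound 3 (0.60 log units; beyond the scatter) and a 3.3-fold lower number from compound 1 to compound 3 (0.52 log units; beyond the scatter), whereas the two bromophenyl compounds stayed within the scatter of each other. No supporting measurement bears on the cause of these steps.

The exchange changes both the halogen and the number of halogens, so the compounds shown do not separate these two changes. From the compounds shown here alone, whether a phenyl carrying a single chlorine, a methoxy group or an amine would give a comparable step remains open.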